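The source may report more compounds than this note shows. Statements on the series, on what has been measured and on what is new or still open speak of the compounds shown alone.

Compound 1, `O=C(CN1CCN(c2ccncc2)CC1)Nc1nc2c(s1)CCCC2`, sits at the bottom of the three measurements gathered so far. In a physicochemical assay for lipophilicity, in phosphate buffer, measured as octanol-water partition, at pH 7.4 (on this read-out higher numbers stand for higher lipophilicity and lower numbers for lower lipophilicity), compound 1 gives 2. Its nearest neighbour on this scale is compound 3, `Cc1nc(NC(=O)CN2CCN(c3ccc(F)cc3)CC2)sc1C`, which in this assay gives 3.7, a gap that lies beyond the scatter. The furthest is compound 2, `O=C(CN1CCN(c2ccc(F)cc2)CC1)Nc1nc2c(s1)CCCCC2`, which in this assay gives 5, again well beyond the scatter. None of these three pairs differs in only one place, so their gaps cannot be tied to a single change.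

Compound 4, `O=C(CN1CCN(c2ccccn2)CC1)Nc1nc2c(s1)CCCC2`, has not yet been measured. It differs from compound 1 in one place: pyridin-2-yl in place of pyridin-4-yl on an amine nitrogen in a ring. The two compounds contain the same atoms, joined differently, and neither the donor nor the acceptor count changes.

For the measured compounds named here, no pair among the measured compounds shows what moving the ring nitrogen of a pyridyl group does on this scale, so the expectation rests on the change alone. An upward step of modest size in this assay is expected, of the order of a number 0.70 log units higher from compound 1 to compound 4 (beyond the scatter), though a result within the scatter of compound 1 would not be surprising. Compound 4 is therefore estimated at 2.7, within a range from 2 to 3.4.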

Compound 4, distribution coefficient: 3.9
For compound 4 the middle estimate is 1.20 log units below the measured one, and the stated range ends below it.
By their numbers in this assay, from the lowest: compound 1; then compounds 3 and 4 (each within the scatter of the next); then compound 2.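

In this assay, for the compounds shown here, this is the first pair differing in one place, so a single change can now be read: pyridin-2-yl in place of pyridin-4-yl on an amine nitrogen in a ring gives a number 1.90 log units higher from compound 1 to compound 4 (beyond the scatter), a large step. The two compounds have the same atoms and the same hydrogen-bond donor and acceptor counts, so on this scale the result at this position is not set by the composition of the group alone; how the same atoms are joined matters too. Nothing available here accounts for the size of the step or says why this rearrangement gives it.

This single pair leaves open whether pyridin-3-yl, or a phenyl ring carrying a methoxy group or a nitrile, on the same amine nitrogen would read closer to compound 1 or to compound 4. It also leaves open whether the same exchange of pyridin-4-yl for pyridin-2-yl would give a step of similar size on a core other than that of compound 1.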